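The source may report more compounds than this note shows. Statements on the series, on what has been measured and on what is new or still open speak of the compounds shown alone.

In a functional assay on SW1573 cells (Homo sapiens) for antiproliferative activity, read by sulforhodamine B assay, with a stated time of 48 h (a lower number here means a stronger inhibitor of growth, a higher number a weaker inhibitor of growth), compound 1 `CCCCC(C#CC(=O)OC)O/C=C/C(=O)OC` gives 240 nM and holds the lowest number shown. Compound 3 `C#CC(O/C=C/C(=O)OC)c1ccccc1` stands far higher at 31000 nM and that gap lies beyond the scatter. Compound 2 `CCCCCCC(C#CC(=O)O)O/C=C/C(=O)OC` reads > 100000 nM which is a limit of the assay and not a number. Compound 4 `CCC(C#CC(=O)OC)O/C=C/C(=O)OC` is still unmeasured and differs from compound 1 by hydrogen in place of ethyl on a saturated chain carbon, three bonds along the chain from an oxygen on an unsaturated carbon and a triple-bonded carbon in one change: hydrogen in place of ethyl on a saturated chain carbon, so that butyl becomes ethyl. Within the data shown here, no measured pair isolates this change. In this assay a moderate rise beyond the scatter is expected, meaning weaker growth inhibition. The estimated move is a 3.8-fold higher number from compound 1 to compound 4 (0.57 log units; beyond the scatter) and it is expected to stop short of the number for compound 3. For compound 4 the expected value is 900 nM with an estimated range from 250 nM to 5000 nM on repeat measurement.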

Compound 4, concentration for 50% growth inhibition: 540 nM
Compound 4: the middle estimate sits 1.7-fold (0.22 log units) above what was measured, within the range that was stated.
By their numbers in this assay, from the lowest: compound 1; then compound 4; then compound 3. At a limit, above all of these: compound 2.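

Shortening butyl to ethyl on this saturated chain carbon gives a 2.3-fold higher number from compound 1 to compound 4 (0.35 log units; beyond the scatter) in this assay. Among these compounds, this is the first comparison that changes one place alone, and it shows that the chain here affects growth inhibition, though only modestly: removing ethyl's worth of chain from the butyl group weakens compound 4 without abolishing its activity. Nothing shown gives a cause for this step. Two chain lengths make one step, not a trend. A methyl group or a longer chain at this position, or an amine at the chain end, could extend or break it.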